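Methyl to methoxy on the benzyl arm: compound 4

A few compounds are considered here, and "the series" means these few. Any claim that something is new, unique, unknown or untested is made for them only; others in the source may bear on it.

Measured so far in an assay on isolated protein for inhibition of aldehyde dehydrogenase 1A1 (Homo sapiens), read by spectrophotometry, tested at 10 uM; on this read-out lower numbers stand for less inhibition and higher numbers for more inhibition at the one concentration tested (going by the name of the read-out):
compound 1 `Cc1cccc(Cn2c(OC3CCN(C(=O)c4ccco4)CC3)nc3ccccc32)c1` gives 68.3%
compound 2 `Cc1ccc(Cn2c(CN3CCN(C(=O)C4CC4)CC3)nc3ccccc32)cc1` gives 51.5%
compound 3 `Cc1cccc(Cn2c(CN3CCN(C(=O)c4ccc(Cl)cc4)CC3)nc3ccccc32)c1` gives 23.2%

Compound 2 holds the second highest of the three numbers in this assay. Compound 1 sits higher by a margin beyond the scatter, and compound 3 sits lower, again beyond the scatter. Going by the values given here, no pair of measured compounds differs in a single place, so no isolated step is available.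

Compound 4 `COc1cccc(Cn2c(CN3CCN(C(=O)C4CC4)CC3)nc3ccccc32)c1` is not yet measured. Its change from compound 2 is 3-methoxyphenyl in place of 4-methylphenyl on a saturated chain carbon bound to an aromatic nitrogen. Among the compounds with values here, nothing among the measured compounds separates this change from other differences, so the expected step is small, in no firm direction, and not beyond the scatter.

For compound 4 the estimate in this assay is 50%, with a range from 30% to 70%. This estimate means an expected step of a number 1.5 percentage points lower from compound 2 to compound 4 (within the scatter), within the usual scatter.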

Compound 4, a percentage reported as inhibition, at one concentration (the size of the read-out at that concentration, not a potency): 44.4%
Beside the measured number, compound 4's estimate is 5.6 percentage points above it, within the range that was stated.
By their numbers in this assay, from the lowest: compound 3; then compounds 4 and 2 (each within the scatter of the next); then compound 1.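

In this assay, the benzyl arm now has its first isolated step: 3-methoxyphenyl in place of 4-methylphenyl gives a number 7.1 percentage points lower from compound 2 to compound 4 (within the scatter). At this position, therefore, the change does not separate the pair beyond repeat-measurement noise, even with the added oxygen and hydrogen-bond acceptor. No supporting data bear on this result.

The step changes both the substituent and its place on the phenyl ring, so the two contributions remain unseparated. From the compounds shown here alone, whether a carboxylic acid or an amine on that ring would shift the number remains open.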